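A few compounds are considered here, and "the series" means these few. Any claim that something is new, unique, unknown or untested is made for them only; others in the source may bear on it.

For the measured compounds named here, compound 2 `CC(C)n1nc(-c2ccnc3[nH]c(C4CCN(CC(=O)N(C)C)CC4)cc23)ccc1=O` gives 3.1 uL/min in an ADME assay on cells (Hepatocyte, Rattus norvegicus) for metabolic stability (on this read-out lower numbers stand for slow clearance and higher numbers for fast clearance), which is the lowest of the two numbers measured so far. Going by the values given here, the only other measured compound, compound 1 `COc1cc(F)ccc1-c1ccnc2[nH]c(C3CCN(CC(=O)N(C)C)CC3)cc12`, gives 38 uL/min in this assay. Among the compounds with values here, the single measured step runs a 12-fold lower number from compound 1 to compound 2 (1.09 log units; beyond the scatter); it exchanged a ring of carbon only for a ring with two hetero atoms, so it shows how strongly this part of the molecule can move the clearance.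

Compound 3 `CC(C)n1cc(-c2ccnc3[nH]c(C4CCN(CC(=O)N(C)C)CC4)cc23)cnc1=O` has not been measured. Compared with compound 2 the change is a group of 10 heavy atoms (7 carbon, 2 nitrogen, 1 oxygen; one six-membered aromatic ring with 2 hetero atoms) in place of a group of 10 heavy atoms (7 carbon, 2 nitrogen, 1 oxygen; one six-membered aromatic ring with 2 hetero atoms), on an aromatic carbon. Here nothing is added or removed: the same atoms are joined differently within a ring of the same size. The measured step from compound 1 to compound 2 does not speak directly to such a rearrangement. That step changed which atoms the ring contains. Within the data shown here, with no measured pair of this kind, the expectation for compound 3 is a step of about a 1.1-fold higher number from compound 2 to compound 3 (0.05 log units; within the scatter), that is, no shift beyond the scatter. Compound 3 is therefore estimated at 3.5 uL/min, with a range from 1.5 uL/min to 9 uL/min.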

Compound 3, intrinsic clearance in a liver preparation (reported as CLH), per the amount of preparation that the assay uses in the Hepatocyte assay: 100 uL/min
Compound 3: the middle estimate sits 29-fold (1.46 log units) below what was measured; measured number above the stated range.
By their numbers in the Hepatocyte assay, from the lowest: compound 2; then compound 1; then compound 3.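

In the Hepatocyte assay, how the same atoms are joined within the ring matters as much as which atoms it contains: with nothing added or removed, the rearrangement gives a 32-fold higher number from compound 2 to compound 3 (1.51 log units; beyond the scatter). A ring with two hetero atoms in place of the ring of carbon only therefore does not by itself bring a lower number, since that exchange can also give a 2.6-fold higher number from compound 1 to compound 3 (0.42 log units; beyond the scatter). In a physicochemical assay for solubility, in phosphate buffer, at pH 7.4 (on this read-out higher numbers stand for higher solubility and lower numbers for lower solubility), compound 2 gives 11000 nM and compound 3 gives 910000 nM, so the same rearrangement also raises solubility: the measured solubility of compound 2, 11000 nM, and of compound 3, 910000 nM, an 83-fold higher number (1.92 log units; beyond the scatter)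

On these data alone, it remains open whether the faster clearance of compound 3 stays with this ring arrangement when the ring carries something else, for instance a methyl or a cyclopropyl group in place of the isopropyl group. As far as these compounds go, it is also open whether clearance and solubility are linked at all, as a single pair in which both numbers rise cannot show a connection between them.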